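Methyl in place of methoxy on compound 2

The source may report more compounds than this note shows. Statements on the series, on what has been measured and on what is new or still open speak of the compounds shown alone.

Of the compounds shown here, two have numbers so far in an ADME assay (liver) for metabolic stability, with Liver microsome (Homo sapiens) as the target, read by LC-MS, using microsomes, with a stated time of 30 min, tested at 4 uM (a lower number here means that less of the compound is left, a higher number that more of the compound is left), and they differ in more than one place. Compound 1 (`CC(=O)NCCn1c(-c2ccccc2Cl)nc2c(N3CCN(C)CC3)nc(C)nc21`) gives 0% as its reading. Compound 2 (`COc1ccccc1-c1nc2c(N3CCN(C)CC3)nc(C)nc2n1C1CCOCC1`) gives 22% as the highest of the two numbers, and its gap to compound 1 lies beyond the scatter.

Compound 3 (`Cc1nc(N2CCN(C)CC2)c2nc(-c3ccccc3C)n(C3CCOCC3)c2n1`) departs from compound 2 by one change: methyl in place of methoxy on an aromatic carbon in words, methyl in place of methoxy on an aromatic carbon, ortho to a large group. Among the compounds with values here, no measured pair shows this change. The reference point is therefore compound 2 at 22% in this series. An estimated step of a number 2 percentage points higher from compound 2 to compound 3 (within the scatter) is expected to stay within the scatter, with no firm direction. For compound 3 the estimate is 24% with an expected range from 7% to 47% in this assay for now.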

Compound 3, percent of the compound remaining: 18%
Compound 3: the middle estimate sits 6 percentage points above what was measured, and the stated range covers the measured number.
By their numbers in this assay, from the lowest: compound 1; then compounds 3 and 2 (each within the scatter of the next).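

In this assay, within the data shown here, the first pair that differs in one place gives a number 4 percentage points lower from compound 2 to compound 3 (within the scatter) for 2-methoxyphenyl to 2-methylphenyl. On this aromatic carbon, ortho to a large group, methyl in place of methoxy therefore produces no readable change, even though the swap removes one heavy atom and the hydrogen-bond acceptor counted on the methoxy. Nothing available bears on the origin of this result.

On these data alone, whether a different group at this position, such as a nitrile, trifluoromethyl or a carboxylic acid, would move the reading beyond the scatter remains open. Also open, as far as these compounds go, is whether this change would read the same way elsewhere, as this single pair is the only one that carries it.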